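Cytotoxicity in lung fibroblasts: a benzofuran for a difluorophenyl

This account rests on a few compounds, and the source may have more. Where it says the series, first, only, none or still open, it means among the compounds named here.

Measured compounds and their values:
compound 1 `COc1cccc(OC)c1C(=O)Nc1c[nH]nc1C(=O)Nc1ccncc1`, > 50000 nM in an ADME assay on MRC5 cells (Homo sapiens) for inhibition, with a stated time of 72 h; on this read-out higher numbers stand for an effect only at larger amounts of compound and lower numbers for an effect already at smaller amounts
compound 2 `CO[C@H]1CC[C@H](NC(=O)c2n[nH]cc2NC(=O)c2ccc(F)cc2F)CC1`, 11000 nM
compound 3 `COc1cccc(OC)c1C(=O)Nc1c[nH]nc1C(=O)O`, > 50000 nM

Compound 1 gives only a limit of the assay in this assay, > 50000 nM. Compound 3 likewise reaches only a limit in this assay, > 50000 nM. Going by the values given here, compound 2 is thus the sole compound with a number in this assay, standing at 11000 nM. Among the compounds with values here, the one measured step, a step that the two limits leave unreadable from compound 1 to compound 3, cannot be read because both ends sit at the limit of > 50000 nM in this assay, at which 2 of the 3 values shown sit.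

Compound 4 `CO[C@H]1CC[C@H](NC(=O)c2n[nH]cc2NC(=O)c2cc3ccccc3o2)CC1` differs from compound 2 in one place: 1-benzofuran-2-yl in place of 2,4-difluorophenyl on a carbonyl carbon. Within the data shown here, no measured step touches this kind of change, and the only readable anchor is the value of compound 2. The step from compound 2 to compound 4 is therefore expected to be small, a 1.1-fold higher number from compound 2 to compound 4 (0.04 log units; within the scatter), with no direction to be read from the data. Compound 4 is accordingly expected to give about 12000 nM in this assay, within 3000 nM to 50000 nM, and a result reported only as a limit would not surprise.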

Compound 4, half-maximal effective concentration: 800 nM
Compound 4: middle estimate off by 15-fold (1.18 log units), on the high side; the measured number lies below the stated range.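

In this assay the group on this carbonyl carbon proves to carry real weight: putting 1-benzofuran-2-yl in place of 2,4-difluorophenyl gives a 14-fold lower number from compound 2 to compound 4 (1.14 log units; beyond the scatter) in a series whose other values gave no readable step. Going by these compounds alone, the only earlier step cannot be read, and it gave no sign that a single exchange on an amide-type nitrogen could move the number this far. Nothing in the data shown accounts for the size of this step.

As far as these compounds go, whether a plain phenyl, a furan-2-yl or a 1-benzothiophen-2-yl on the same carbonyl carbon would stay close to compound 2 or to compound 4 remains open. From the compounds shown here alone, it is equally open whether 1-benzofuran-2-yl would act the same way on the core of compound 1, in place of its dimethoxyphenyl group.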